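A few compounds are considered here, and "the series" means these few. Any claim that something is new, unique, unknown or untested is made for them only; others in the source may bear on it.

Working notes on the series. Compound 1 `Cn1c(=O)c(=O)n(C2CCCC2)c2nc(N/N=C/c3ccccc3)ncc21` carries a phenyl on the carbon with a double bond to nitrogen. In a functional assay on HCT-116 cells (Homo sapiens) for antiproliferative activity, read by MTT assay (a higher number here means a weaker inhibitor, a lower number a stronger inhibitor), compound 1 gives only a limit, > 100000 nM, as recorded in the limit of > 100000 nM in this assay, at which 1 of the 3 values shown sits. Compound 2 `Cn1c(=O)c(=O)n(C2CCCC2)c2nc(N/N=C/c3ccc(O)c(F)c3)ncc21` gives 59300 nM in this assay, and compound 3 `Cc1cc(C)c(/C=N/Nc2ncc3c(n2)n(C2CCCC2)c(=O)c(=O)n3C)c(C)c1` gives 7920 nM. Of the two numbers in hand, compound 2 holds the higher; its nearest neighbour is compound 3, reached by a 7.5-fold lower number from compound 2 to compound 3 (0.87 log units; beyond the scatter). The steps of an at least 1.6-fold lower number from compound 1 to compound 2 (0.22 log units; that floor lies within the scatter) and an at least 12-fold lower number from compound 1 to compound 3 (1.10 log units; beyond the scatter) are floors set by that limit.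

Compound 4 `Cn1c(=O)c(=O)n(C2CCCC2)c2nc(N/N=C/c3cccc([N+](=O)[O-])c3)ncc21` is not yet measured. Against compound 2 the change is 3-nitrophenyl in place of 3-fluoro-4-hydroxyphenyl on a carbon with a double bond to nitrogen. All three measured steps concern the aryl on this same carbon and so bear on it: 3-fluoro-4-hydroxyphenyl brought a gain that may be no more than scatter, 2,4,6-trimethylphenyl a large one. Among the compounds with values here, no measured pair carries 3-nitrophenyl, so its effect is open. A small downward step is expected for compound 4, a 2.0-fold lower number from compound 2 to compound 4 (0.30 log units; within the scatter), possibly not beyond the scatter. The estimate for compound 4 in this assay is 30000 nM, with a range from 8000 nM to 100000 nM.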

Compound 4, half-maximal inhibitory concentration: 15200 nM
The estimate for compound 4 lay 2.0-fold (0.30 log units) above the measured number; measured number inside the range.
By their numbers in this assay, from the lowest: compounds 3 and 4 (each within the scatter of the next); then compound 2. At a limit, above all of these: compound 1.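

In this assay the aryl on this carbon need not keep the hydrogen-bond donor of 3-fluoro-4-hydroxyphenyl: 3-nitrophenyl, with 0 hydrogen-bond donors, gives a 3.9-fold lower number from compound 2 to compound 4 (0.59 log units; beyond the scatter). Nitro in place of hydrogen on the phenyl gives an at least 6.5-fold lower number from compound 1 to compound 4 (0.81 log units; beyond the scatter), so a single group on the phenyl now yields a floor that clears the scatter, and that step remains a floor set by the limit of compound 1: the limit of > 100000 nM in this assay, at which 1 of the 4 values shown sits. Nor is 2,4,6-trimethylphenyl alone among the aryl groups any longer, since the step of a 1.9-fold higher number from compound 3 to compound 4 (0.28 log units; within the scatter) does not separate the two.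

From the compounds shown here alone, whether the nitro group must sit as it does in 3-nitrophenyl stays open. So does whether an amine or a carboxylic acid in its place on the same phenyl would hold the number of compound 4.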